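The source may report more compounds than this note shows. Statements on the series, on what has been measured and on what is new or still open speak of the compounds shown alone.

Measured so far:
compound 1, `CCN1CCC(N2CCN(c3ccccc3)CC2)C(O)C1`: > 1000 nM
compound 2, `OC1CCN(Cc2ccccc2)CC1N1CCN(c2ccccc2)CC1`: > 100 nM

In an assay on PC-12 cells for displacement of a labelled ligand from vesicular acetylcholine transporter (Homo sapiens) (on this read-out higher numbers stand for weaker inhibition and lower numbers for stronger inhibition), compound 2 gives > 100 nM, a limit of the assay and not a number (the limit of > 100 nM in this assay, at which 1 of the 2 values shown sits). Compound 1 likewise reaches only a limit, > 1000 nM (the limit of > 1000 nM in this assay, at which 1 of the 2 values shown sits). Compound 3, `C=CCN1CCC(O)C(N2CCN(c3ccccc3)CC2)C1`, differs from compound 2 by vinyl in place of phenyl on a saturated chain carbon bound to an amine nitrogen in a ring. Within the data shown here, no step between measured compounds is available, and with both measured values sitting at limits no direction can be read; a step beyond the scatter is not expected in either direction. Compound 3 is therefore estimated at 3000 nM, range 300 nM to 30000 nM. The expected step is a step that the limit leaves unreadable from compound 2 to compound 3, most likely again reported only as a limit.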

Compound 3, half-maximal inhibitory concentration: > 100 nM
Compound 3: no number, only a limit; the forecaster's own chance of this, stated with the estimate: 70%; the middle value does not contradict the limit.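

Compound 2 and compound 3 both stand only at limits in this assay, so no step can be read between them. The compounds shown leave open whether vinyl in place of phenyl changes inhibition at all.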